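Methoxy in Place of Methylsulfanyl on a Shared Core

A few compounds are considered here, and "the series" means these few. Any claim that something is new, unique, unknown or untested is made for them only; others in the source may bear on it.

Measured so far:
compound 1, `COc1nc2nc(C(=O)c3ccccc3)cn2c(C)c1CC1CC1`, 10 mg/kg
compound 2, `CSc1cc(C)n2cc(C(=O)c3ccccc3)nc2n1`, 5 mg/kg

Both compounds were tested in a functional assay on the whole organism with Rattus norvegicus as the target; on this read-out lower numbers stand for an effect already at smaller amounts and higher numbers for an effect only at larger amounts of compound. Among the two numbers, compound 2 stands at the lowest; the nearest is compound 1, whose number is higher by an amount that lies within the usual scatter, so the two cannot be ranked against each other.

Compound 3, `COc1cc(C)n2cc(C(=O)c3ccccc3)nc2n1`, has not yet been measured. It differs from compound 2 in one place: methoxy in place of methylsulfanyl on an aromatic carbon. Among the compounds with values here, no pair of measured compounds differs in that single place, so nothing recorded shows what this exchange does on its own. Compound 1 also carries a methoxy group, but it differs from compound 2 in more than one place, and its value only shows that it sits close to compound 2.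

With nothing to point in either direction, the step of no change at the digits printed from compound 2 to compound 3 (within the scatter) is expected to stay within the scatter. For compound 3 in this assay the estimate is 5 mg/kg, with a range from 2 mg/kg to 15 mg/kg.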

Compound 3, minimum effective dose: 5 mg/kg
Compound 3: middle estimate and measured number agree at the digits printed; low and high end bracket the measured number.
By their numbers in this assay, from the lowest: compounds 2, 3 and 1 (each within the scatter of the next).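

In this assay, the exchange of methylsulfanyl for methoxy on this aromatic carbon can now be read on its own: no change at the digits printed from compound 2 to compound 3 (within the scatter), so on this core the two groups cannot be told apart by this read-out. Compound 3 also connects to compound 1 through a single difference, hydrogen in place of cyclopropylmethyl on an aromatic carbon, and that step, a 2.0-fold lower number from compound 1 to compound 3 (0.30 log units; within the scatter), likewise shows no separation in this assay. Nothing measured here explains why either exchange leaves the values within the scatter.

Still open, as far as these compounds go, is whether a quite different group in the place of the methoxy, such as an amine or a longer chain like butoxy, would stay within the scatter too. These steps also leave open whether the same exchanges would give the same result on another core.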